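From pyridin-3-yl to 2,3,4-trifluorophenyl on a shared core

A few compounds are considered here, and "the series" means these few. Any claim that something is new, unique, unknown or untested is made for them only; others in the source may bear on it.

Three amides of the shared core have been measured in an ADME assay on L6 cells (Rattus norvegicus) for cytotoxicity; on this read-out higher numbers stand for weaker inhibition and lower numbers for stronger inhibition. Compound 1 `O=C(Nc1c(O)cccc1-c1nc2c(C(=O)O)cccc2o1)c1ccccn1`, with pyridin-2-yl on the carbonyl carbon, gives 30600 nM. Compound 2 `O=C(Nc1c(O)cccc1-c1nc2c(C(=O)O)cccc2o1)c1ccccc1O`, with 2-hydroxyphenyl there, gives 85100 nM. Compound 3 `O=C(Nc1c(O)cccc1-c1nc2c(C(=O)O)cccc2o1)c1cccnc1`, with pyridin-3-yl, gives 240000 nM, the highest number of the three and so the weakest inhibition in this assay.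

Compound 4 `O=C(Nc1c(O)cccc1-c1nc2c(C(=O)O)cccc2o1)c1ccc(F)c(F)c1F` has not yet been measured. It carries 2,3,4-trifluorophenyl in place of the pyridin-3-yl of compound 3, on a carbonyl carbon whose other neighbour is the amide-type nitrogen: 2,3,4-trifluorophenyl in place of pyridin-3-yl on a carbonyl carbon.

Within the data shown here, two measured steps bear on this change: a 7.8-fold higher number from compound 1 to compound 3 (0.89 log units; beyond the scatter) and a 2.8-fold higher number from compound 2 to compound 3 (0.45 log units; beyond the scatter). Both are modest and beyond the scatter, and both end at compound 3. The second is the closer guide, since compound 2 also has a six-membered aromatic ring of carbon only. Among the measured compounds shown here, no measured compound carries fluorine, so this guidance is limited. Among these three compounds, both other groups give lower numbers than pyridin-3-yl, so a modest move towards a lower number is expected. The expected change is a 3.4-fold lower number from compound 3 to compound 4 (0.54 log units; beyond the scatter). Compound 4 is estimated at 70000 nM, with an expected range from 20000 nM to 200000 nM.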

Compound 4, half-maximal inhibitory concentration: 210000 nM
Compound 4: the middle estimate sits 3.0-fold (0.48 log units) below what was measured; measured number above the stated range.
By their numbers in this assay, from the lowest: compound 1; then compound 2; then compounds 4 and 3 (each within the scatter of the next).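

In this assay, 2,3,4-trifluorophenyl in place of pyridin-3-yl on the carbonyl carbon gives a 1.1-fold lower number from compound 3 to compound 4 (0.06 log units; within the scatter), so exchanging a ring with a hetero atom for a ring of carbon only does not separate these two compounds at this position. A ring of carbon only does not by itself fix the read-out, as 2,3,4-trifluorophenyl in place of 2-hydroxyphenyl gives a 2.5-fold higher number from compound 2 to compound 4 (0.39 log units; beyond the scatter), although both groups are six-membered aromatic rings of carbon only. Pyridin-2-yl still gives the lowest number of the four, since 2,3,4-trifluorophenyl in its place gives a 6.9-fold higher number from compound 1 to compound 4 (0.84 log units; beyond the scatter), and that group's steps to compounds 2 and 3 are also beyond the scatter.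

The compounds shown leave open how an amine or a carboxylic acid on the aromatic ring, or a longer chain in place of the ring on the carbonyl carbon, would read in this assay. Nothing given here accounts for the differences among these four compounds.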